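The compounds below may be only part of what the source reports. "The series", "measured", "known", "first", "only" and "open" are said of these compounds alone.

Two compounds share a core that has been measured in an assay for inhibition of inositol hexakisphosphate kinase 2 (Homo sapiens), read by colorimetric assay, coupled enzyme assay and malachite green, with a stated time of 120 min, in the presence of a further agent that is not named here; on this read-out lower numbers stand for stronger inhibition and higher numbers for weaker inhibition. Compound 1 `O=C(O)c1ccc2noc(-c3ccc(-c4cccnc4)cc3)c2c1` gives 54 nM in this assay, and compound 2 `O=C(O)c1ccc2noc(-c3ccc(N4CCCCC4)cc3)c2c1` gives 240 nM. Within the data shown here, compound 2 stands at the higher of the two numbers, and the one step between them, a 4.4-fold higher number from compound 1 to compound 2 (0.65 log units; beyond the scatter), is the only measured step this series offers. Compound 3 `O=C(O)c1ccc2noc(-c3ccc(Cc4ccccc4)cc3)c2c1` differs from compound 2 by benzyl in place of piperidin-1-yl on an aromatic carbon. The step from compound 1 to compound 2 bears on it only in part: it shows that replacing an aromatic ring by a saturated one at this position raised the number, so putting an aromatic ring back, though through a one-carbon linker and without the acceptor, gives grounds to expect a step in the opposite direction, of modest size, in this assay. The estimated step of a 2.4-fold lower number from compound 2 to compound 3 (0.38 log units; beyond the scatter) is therefore expected to bring compound 3 to about 100 nM, with a range from 35 nM to 300 nM.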

Compound 3, half-maximal inhibitory concentration: 65 nM
Compound 3: middle estimate off by 1.5-fold (0.19 log units), on the high side; measured number inside the range.
By their numbers in this assay, from the lowest: compounds 1 and 3 (each within the scatter of the next); then compound 2.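

In this assay, benzyl in place of piperidin-1-yl on this aromatic carbon gives a 3.7-fold lower number from compound 2 to compound 3 (0.57 log units; beyond the scatter) and so reverses most of the rise seen on going to the saturated ring. Benzyl in place of pyridin-3-yl gives a 1.2-fold higher number from compound 1 to compound 3 (0.08 log units; within the scatter) and the two cannot be told apart on this read-out, so among these compounds neither a ring joined directly to the aromatic carbon nor a ring nitrogen is needed for a number in this range. Of the three groups, only piperidin-1-yl, the one non-aromatic ring, stands apart.

Going by these compounds, it remains open whether a cyclohexylmethyl group would match benzyl, which would separate the one-carbon linker from the aromatic ring, and whether a 2-phenylethyl chain or a phenoxy group would be tolerated at this position. Nothing available here accounts for the gap between piperidin-1-yl and the two aromatic groups.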